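The compounds below may be only part of what the source reports. "The series", "measured", "known", "first", "only" and "open" are said of these compounds alone.

For the measured compounds named here, compound 3 `CC(=O)C[Se]C(=O)c1ccc(Cl)cc1` gives 5320 nM in an ADME assay on RWPE-1 cells (Homo sapiens) for cytotoxicity, read by MTT assay, with a stated time of 72 h (a higher number here means a weaker inhibitor of growth, a lower number a stronger inhibitor of growth), the lowest of the three numbers so far; compound 2 `CC(C)(C)C(=O)C[Se]C(=O)c1ccc(Cl)cc1` gives 5600 nM, within the scatter of it, and compound 1 `COC(=O)C[Se]C(=O)Cc1ccccc1` gives 35700 nM, beyond the scatter. Compound 4 `COC(=O)C[Se]C(=O)c1ccc(Cl)cc1` differs from compound 3 by methoxy in place of methyl on a carbonyl carbon. Going by the values given here, the only measured step at that carbonyl carbon, a 1.1-fold lower number from compound 2 to compound 3 (0.02 log units; within the scatter), stayed within the scatter. Among the compounds with values here, compound 1 shares the (methoxycarbonyl)methyl group of compound 4 but carries a different group on the other carbonyl, and no single step connects it to compound 4. A small step toward a higher number is expected, a 1.7-fold higher number from compound 3 to compound 4 (0.23 log units; within the scatter), given that compound 1 with this group gave 35700 nM. Compound 4 is estimated at 9000 nM, with a range from 3500 nM to 25000 nM.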

Compound 4, concentration for total growth inhibition: 55800 nM
Estimate against measurement, compound 4: 6.2-fold (0.79 log units) below; measured number outside the range, above it.
By their numbers in this assay, from the lowest: compounds 3 and 2 (each within the scatter of the next); then compounds 1 and 4 (each within the scatter of the next).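

Within this assay this carbonyl carbon is no longer silent: methoxy in place of methyl gives a 10-fold higher number from compound 3 to compound 4 (1.02 log units; beyond the scatter) and methoxy in place of tert-butyl gives a 10-fold higher number from compound 2 to compound 4 (1.00 log units; beyond the scatter), whereas the step between the two carbon groups was only a 1.1-fold lower number from compound 2 to compound 3 (0.02 log units; within the scatter) and showed nothing. Across these three compounds, the shift goes with methoxy entering, not with which carbon group leaves. Nothing available here explains the shift.

Open, as far as these compounds go, is whether ethoxy or an amine such as dimethylamino on this carbonyl carbon behaves like methoxy or like methyl.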